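Swapping a Pentyl for a Fluoro on the Aromatic Ring

A few compounds are considered here, and "the series" means these few. Any claim that something is new, unique, unknown or untested is made for them only; others in the source may bear on it.

Compound 1, `CCCCCCS(=O)(=O)N[C@H]1C2CC[C@H](C2)[C@@H]1C/C=C\CCCC(=O)O`: 13300 nM
Compound 2, `CCCCCc1ccc(S(=O)(=O)N[C@H]2C3CC[C@H](C3)[C@@H]2C/C=C\CCCC(=O)O)cc1`: 800000 nM

Of the compounds shown here, two have been measured in a functional assay (plasma) for inhibition, with Oryctolagus cuniculus as the target; a higher number here means a weaker inhibitor, a lower number a stronger inhibitor. Compound 1 gives 13300 nM, while compound 2 gives 800000 nM. Compound 2 therefore stands at the highest of the two numbers, and its gap to compound 1 lies well beyond the usual scatter, so compound 2 is clearly the weaker inhibitor of the pair.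

Compound 3, `O=C(O)CCC/C=C\C[C@H]1[C@@H]2CCC(C2)[C@@H]1NS(=O)(=O)c1ccc(F)cc1`, has not yet been measured in this assay. It differs from compound 2 in one place: fluoro in place of pentyl on an aromatic carbon. The group that leaves sits on an aromatic carbon of a six-membered aromatic ring of carbon only, para to a large group, and a single fluorine takes its place.

Going by the values given here, no measured pair shows this exact change, so the expectation rests on the two numbers alone. Compound 3 is expected to give 200000 nM, within a range of 30000 nM to 1000000 nM. This estimate means a step of a 4.0-fold lower number from compound 2 to compound 3 (0.60 log units; beyond the scatter), a modest gain in potency, though a result within the scatter of compound 2 would not be surprising.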

Compound 3, half-maximal inhibitory concentration: 600 nM
Beside the measured number, compound 3's estimate is 330-fold (2.52 log units) above it; measured number outside the range, below it.
By their numbers in this assay, from the lowest: compound 3; then compound 1; then compound 2.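

In this assay, the group on this aromatic carbon matters far more than the first two compounds could show: fluoro in place of pentyl gives a 1300-fold lower number from compound 2 to compound 3 (3.12 log units; beyond the scatter), a large step. The aromatic ring itself is therefore compatible with a low number, and the high number of compound 2 goes with the pentyl group that the ring carries, para to a large group, rather than with the ring alone. The change at the sulfonyl sulfur points the same way, as 4-fluorophenyl in place of hexyl gives a 22-fold lower number from compound 1 to compound 3 (1.35 log units; beyond the scatter), which leaves compound 3 with the lowest number of the three.

Nothing at hand explains why either step is so large. The compounds shown leave open whether fluoro itself is needed or whether a plain hydrogen, chloro or methoxy on the same carbon would serve as well, and whether a short chain such as methyl or ethyl would stay close to compound 3 or move towards compound 2.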